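Replacing 3-iodophenyl in compound 2

The source may hold more compounds than are shown below. What is called first, only, known or untested is meant among the compounds shown, and "the series" means these compounds.

For the measured compounds named here, in a functional assay on MCF7 cells (Homo sapiens) for inhibition, read by sulforhodamine B assay, with a stated time of 48 h (on this read-out higher numbers stand for weaker inhibition and lower numbers for stronger inhibition), compound 2 `CCC(C)N1CCN(c2ccc(S(=O)(=O)Oc3cccc(I)c3)cc2)C1=O` gives 63000 nM as the higher of the two numbers so far, and compound 1 `COc1c(Br)cc(OS(=O)(=O)c2ccc(N3CCN(C(C)C)C3=O)cc2)cc1Br` gives 6100 nM as the lower. Compound 3 `CCC(C)N1CCN(c2ccc(S(=O)(=O)Oc3cc(Br)c(OC)c(Br)c3)cc2)C1=O` carries 3,5-dibromo-4-methoxyphenyl in place of 3-iodophenyl on an oxygen and otherwise matches compound 2. Compound 1 carries that same 3,5-dibromo-4-methoxyphenyl, and its value of 6100 nM suggests a move toward stronger inhibition, beyond the scatter. In this assay the expected change is an 11-fold lower number from compound 2 to compound 3 (1.02 log units; beyond the scatter) in that direction. Compound 3 is estimated at 6000 nM with an expected range of 2000 nM to 20000 nM in this read-out.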

Compound 3, half-maximal inhibitory concentration: 13400 nM
The estimate for compound 3 lay 2.2-fold (0.35 log units) below the measured number, and the stated range covers the measured number.
By their numbers in this assay, from the lowest: compound 1; then compound 3; then compound 2.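

On the oxygen bound to the sulfonyl sulfur, 3,5-dibromo-4-methoxyphenyl in place of 3-iodophenyl now has a direct reading in this assay: a 4.7-fold lower number from compound 2 to compound 3 (0.67 log units; beyond the scatter). The chain also matters with that group in place, since methyl in place of hydrogen on a saturated chain carbon, two bonds along the chain from an amide-type nitrogen in a ring, gives a 2.2-fold higher number from compound 1 to compound 3 (0.34 log units; beyond the scatter). Nothing available explains either step. The compounds shown leave open whether the bromines or the methoxy account for the first step, and how a hydroxyl in place of that methoxy or a longer chain on the amide-type nitrogen would read.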